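Diethylcarbamoyl in place of cyano on the side chain

The source may report more compounds than this note shows. Statements on the series, on what has been measured and on what is new or still open speak of the compounds shown alone.

Among the compounds with values here, in a functional assay on T-24 cells (Homo sapiens) for cytotoxicity, read by colorimetric assay and MTT assay (on this read-out lower numbers stand for stronger inhibition and higher numbers for weaker inhibition), compound 1 `COc1ccc(-c2cc3c(OC)cc(OC)cc3n(CC(=O)O)c2=O)cc1` gives 10000 nM and compound 2 `COc1ccc(-c2cc3c(OC)cc(OC)cc3n(CCC#N)c2=O)cc1` gives 10000 nM, so compound 2 stands level with its only measured neighbour. Compound 3 `CCN(CC)C(=O)CCn1c(=O)c(-c2ccc(OC)cc2)cc2c(OC)cc(OC)cc21` keeps the shared core but carries diethylcarbamoyl in place of cyano on a saturated chain carbon, two bonds along the chain from an aromatic nitrogen. Within the data shown here, the one measured step that bears on this, no change at the digits printed from compound 1 to compound 2 (within the scatter), also altered the end of this side chain and stayed within the scatter. The expected step is therefore similar, with none beyond the scatter: no change at the digits printed from compound 2 to compound 3 (within the scatter). For compound 3 the estimate is 10000 nM, with an expected range from 4000 nM to 20000 nM.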

Compound 3, half-maximal inhibitory concentration: 10000 nM
The estimate for compound 3 equals the measured number at the digits printed; the measured number falls inside the stated range.
By their numbers in this assay, from the lowest: compounds 1, 2 and 3 (each within the scatter of the next).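

In this assay, the larger diethylcarbamoyl group in place of cyano gives no change at the digits printed from compound 2 to compound 3 (within the scatter), and (diethylcarbamoyl)methyl in place of carboxy gives no change at the digits printed from compound 1 to compound 3 (within the scatter). The end of this side chain has now been carboxy, cyano and diethylcarbamoyl, and all three compounds read alike, so this amide adds nothing measurable over either earlier group. On these data alone, whether a basic amine at the chain end or a longer chain would separate from these three stays open. No supporting measurement is available to explain this sameness.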